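This account rests on a few compounds, and the source may have more. Where it says the series, first, only, none or still open, it means among the compounds named here.

Compound 2 `C/C=C\Oc1cncc(N2CCCNCC2)c1` sits second highest of the three values measured in an assay on HEK293 cells with Neuronal acetylcholine receptor; alpha4/beta2 (Homo sapiens) as the target, read by FLIPR and calcium flux (a higher number here means a larger maximal response, a lower number a smaller maximal response), where compound 2 reaches 45%. Below it, beyond the scatter, compound 3 `c1ccc2ncc(N3CCCNCC3)cc2c1` gives 33%; far above it, also beyond the scatter, compound 1 `COc1cc(N2CCCNCC2)cnc1Cl` gives 116%. Compound 4 `COc1cncc(N2CCCNCC2)c1` has not yet been measured. It differs from compound 2 in one place: methyl in place of prop-1-en-1-yl on an oxygen on an aromatic ring. Going by the values given here, no pair of measured compounds isolates this change, so its effect has to be judged from the three values alone. Compound 1, which also carries a methyl on an aromatic oxygen, gives 116%, which points upward, though compound 1 differs in other places too. A moderate rise, a number 17 percentage points higher from compound 2 to compound 4 (beyond the scatter), is expected. For compound 4 the estimate in this assay is 62%, between 32% and 95%.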

Compound 4, largest response reached (reported as efficacy), in percent of the reference or control that the assay uses: 66%
Compound 4: middle estimate off by 4 percentage points, on the low side; low and high end bracket the measured number.
By their numbers in this assay, from the lowest: compound 3; then compound 2; then compound 4; then compound 1.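

In this assay, the prop-1-en-1-yl on the aromatic oxygen is not required for a response, and methyl in its place gives a number 21 percentage points higher from compound 2 to compound 4 (beyond the scatter). Going by these compounds alone, compound 4 also isolates the chloro on an aromatic carbon for the first time: hydrogen in place of chloro gives a number 50 percentage points lower from compound 1 to compound 4 (beyond the scatter), the larger of the two steps.

Nothing shown explains either step. As far as these compounds go, whether an ethyl or a longer chain on the oxygen would follow the same direction, and whether fluoro or bromo could stand in for chloro, remains open.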